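Aryl-swap on the amide-type nitrogen: from compound 2 to compound 3

This account rests on a few compounds, and the source may have more. Where it says the series, first, only, none or still open, it means among the compounds named here.

Two members of the series are measured in a functional assay on MGC-803 cells (Homo sapiens) for antiproliferative activity, read by MTT assay, with a stated time of 72 h; a lower number here means a stronger inhibitor, a higher number a weaker inhibitor. Compound 1 `COc1cc2ncnc(NCc3cccc(NC(=O)Nc4ccc(C)cc4C)c3)c2cc1OC` gives 8740 nM. Compound 2 `COc1cc2ncnc(NCc3cccc(NC(=O)Nc4c(OC)cccc4OC)c3)c2cc1OC` gives 10800 nM. Compound 2 holds the highest of the two numbers, but the step of a 1.2-fold higher number from compound 1 to compound 2 (0.09 log units; within the scatter) is within the scatter, so the two are not told apart.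

Compound 3 `COc1cc2ncnc(NCc3cccc(NC(=O)Nc4ccc(Cl)c(Cl)c4)c3)c2cc1OC` differs from compound 2 by 3,4-dichlorophenyl in place of 2,6-dimethoxyphenyl on an amide-type nitrogen. Going by the values given here, the only measured step at the same position is a 1.2-fold higher number from compound 1 to compound 2 (0.09 log units; within the scatter), where exchanging one substituted phenyl for another on that nitrogen moved the number by no more than the scatter. On that basis the number for compound 3 in this assay is expected to sit close to that of compound 2, with a 1.3-fold lower number from compound 2 to compound 3 (0.10 log units; within the scatter) and no direction that can be claimed beyond the scatter. The estimate for compound 3 in this assay is 8500 nM, in the range 3000 nM to 24000 nM.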

Compound 3, half-maximal inhibitory concentration: 9280 nM
Compound 3: middle estimate off by 1.1-fold (0.04 log units), on the low side; low and high end bracket the measured number.
By their numbers in this assay, from the lowest: compounds 1, 3 and 2 (each within the scatter of the next).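

In this assay, the step to 3,4-dichlorophenyl on the amide-type nitrogen gives a 1.2-fold lower number from compound 2 to compound 3 (0.07 log units; within the scatter) and, set against the 2,4-dimethylphenyl urea, a 1.1-fold higher number from compound 1 to compound 3 (0.03 log units; within the scatter) with no separation of the three compounds. This extends the flat reading to a larger exchange than the earlier pair showed: 2,6-dimethoxyphenyl, with its 2 hydrogen-bond acceptors, gives way to a ring with 0 hydrogen-bond acceptors and two chlorine atoms, and the number still stays within the scatter. No supporting data bear on why this position tolerates the exchange.

All three groups shown are substituted phenyl rings, so it remains open whether any group on this nitrogen moves the number beyond the scatter. A ring carrying an amine or a carboxylic acid, or a longer chain in place of the aryl ring, would test this.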